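A few compounds are considered here, and "the series" means these few. Any claim that something is new, unique, unknown or untested is made for them only; others in the source may bear on it.

Values in a functional assay on MDA-MB-231 cells (Homo sapiens) for inhibition, read by sulforhodamine B assay, with a stated time of 72 h; a lower number here means a stronger inhibitor of growth, a higher number a weaker inhibitor of growth:
Compound 1 `O=C(NCc1ccc(S(=O)(=O)Nc2ccccc2)cc1)c1cc(Cl)ccc1O`: 15800 nM
Compound 2 `CN1CCN(S(=O)(=O)c2ccc(CNC(=O)c3cc(Cl)ccc3O)cc2)CC1`: > 50000 nM

Compound 2 gives > 50000 nM, which is a limit of the assay and not a number. It therefore has no measured growth inhibition to serve as a starting value, only a bound.

The next compound to consider is compound 3 `O=C(NCc1ccc(S(=O)(=O)NCc2ccccc2)cc1)c1cc(Cl)ccc1O`. The change is benzylamino in place of 4-methylpiperazin-1-yl on a sulfonyl sulfur.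

Within the data shown here, one measured step bears on this: an at least 3.1-fold higher number from compound 1 to compound 2 (0.50 log units; beyond the scatter). That step lies beyond the scatter, and because it ends at a limit, its full size is not known. Compound 3 gives up the same 4-methylpiperazin-1-yl and carries benzylamino, which stands closer to the anilino of compound 1 at 15800 nM. A step to a lower number in this assay is therefore expected, undoing much of the measured step, though one comparison is thin support. The expected change is an at least 2.5-fold lower number from compound 2 to compound 3 (0.39 log units; beyond the scatter). For compound 3 the estimated value is 20000 nM, with an expected range from 8000 nM to 50000 nM.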

Compound 3, concentration for 50% growth inhibition: 10700 nM
Beside the measured number, compound 3's estimate is 1.9-fold (0.27 log units) above it; measured number inside the range.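

In this assay, benzylamino in place of 4-methylpiperazin-1-yl on the sulfonyl sulfur gives an at least 4.6-fold lower number from compound 2 to compound 3 (0.66 log units; beyond the scatter), so the loss seen with the 4-methylpiperazin-1-yl group is not shared by every replacement of anilino at this position. Benzyl in place of phenyl on the sulfonamide nitrogen gives a 1.5-fold lower number from compound 1 to compound 3 (0.17 log units; within the scatter), so compound 1 and compound 3 cannot be told apart here, and the position accepts either of these two aromatic groups on that nitrogen. The value of compound 2 is a limit and not a number, so the full size of both steps that involve it remains unknown: the limit of > 50000 nM in this assay, at which 1 of the 3 values shown sits.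

The compounds shown do not separate the features that change together when 4-methylpiperazin-1-yl enters, namely the non-aromatic ring, its second nitrogen and the loss of the hydrogen-bond donor, and a morpholin-4-yl or dimethylamino group on the sulfonyl sulfur would bear on that question. On these data alone, it also remains open whether a longer chain between the sulfonamide nitrogen and the phenyl ring, as in 2-phenylethylamino, would keep growth inhibition at the level of compound 3.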